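Shortening the alkoxy chain of a benzyl formamide

The source may hold more compounds than are shown below. What is called first, only, known or untested is meant among the compounds shown, and "the series" means these compounds.

Compound 1 `NC(=O)C(F)F`: 75900000 nM
Compound 2 `CCCCCOc1ccc(CNC=O)cc1`: 30.2 nM

In an assay for inhibition of alcohol dehydrogenase (Equus caballus) (on this read-out higher numbers stand for weaker inhibition and lower numbers for stronger inhibition), compound 1 gives 75900000 nM. Compound 2 gives 30.2 nM, the lower of the two numbers and far from the value of compound 1. Compound 3 `CCCCOc1ccc(CNC=O)cc1` differs from compound 2 by hydrogen in place of methyl on a saturated chain carbon, four bonds along the chain from an oxygen on an aromatic ring. Within the data shown here, no measured pair shows the effect of such a change, so the step is uncertain; a small move toward weaker inhibition, near the scatter, seems the likeliest outcome. Compound 3 is therefore expected to give 60 nM, within 20 nM to 200 nM, a step of a 2.0-fold higher number from compound 2 to compound 3 (0.30 log units; within the scatter).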

Compound 3, inhibition constant: 39.8 nM
For compound 3 the middle estimate is 1.5-fold (0.18 log units) above the measured one, and the stated range covers the measured number.
By their numbers in this assay, from the lowest: compounds 2 and 3 (each within the scatter of the next); then compound 1.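

In this assay, hydrogen in place of methyl on this saturated chain carbon, four bonds along the chain from an oxygen on an aromatic ring, gives a 1.3-fold higher number from compound 2 to compound 3 (0.12 log units; within the scatter). Among these compounds, this is the first reading at this position, and it shows that losing the methyl leaves the two compounds indistinguishable on this read-out. Nothing available explains this result. As far as these compounds go, whether a still shorter chain, a longer chain, or an amine or carboxylic acid in place of the methyl would keep the number in this range remains open.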